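Swapping Cyclohexyl for 3-Methylphenyl on the Nitrogen

This account rests on a few compounds, and the source may have more. Where it says the series, first, only, none or still open, it means among the compounds named here.

Measured so far in a physicochemical assay for solubility, with a stated time of 24 h, tested at 30 mg/mL; on this read-out lower numbers stand for lower solubility and higher numbers for higher solubility:
- compound 1 `O=C(CCCCCNc1c(NCc2ccccc2)c(=O)c1=O)NO`: 5700000 nM
- compound 2 `C[C@H](Nc1c(NCCCCCC(=O)NO)c(=O)c1=O)c1ccccc1`: 28000000 nM
- compound 3 `O=C(CCCCCNc1c(NC2CCCCC2)c(=O)c1=O)NO`: 8700000 nM

Compound 3 cannot be told apart from compound 1 on these numbers, while compound 2 stands higher than both. Compound 4 `Cc1cccc(Nc2c(NCCCCCC(=O)NO)c(=O)c2=O)c1` carries 3-methylphenyl in place of cyclohexyl on a nitrogen on an aromatic ring. Two measured swaps at this nitrogen also involve cyclohexyl. One gave a 1.5-fold higher number from compound 1 to compound 3 (0.18 log units; within the scatter), and the other gave a 3.2-fold lower number from compound 2 to compound 3 (0.51 log units; beyond the scatter). Together they fix no firm direction, and no measured compound has 3-methylphenyl there. No step beyond the scatter is therefore expected in this assay. The expected step is a 1.5-fold lower number from compound 3 to compound 4 (0.16 log units; within the scatter). The estimate for compound 4 is 6000000 nM, with an expected range from 2000000 nM to 18000000 nM.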

Compound 4, solubility: 11000000 nM
For compound 4 the middle estimate is 1.8-fold (0.26 log units) below the measured one; the measured number falls inside the stated range.
By their numbers in this assay, from the lowest: compounds 1, 3 and 4 (each within the scatter of the next); then compound 2.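

In this assay, 3-methylphenyl on this nitrogen gives a number that cannot be told apart from that with the non-aromatic cyclohexyl (a 1.3-fold higher number from compound 3 to compound 4 (0.10 log units; within the scatter)) or with benzyl (a 1.9-fold higher number from compound 1 to compound 4 (0.29 log units; within the scatter)). Among these four compounds, only the 1-phenylethyl of compound 2 stands apart, here by a modest step (a 2.5-fold lower number from compound 2 to compound 4 (0.41 log units; beyond the scatter)). Nothing measured here explains these steps. As far as these compounds go, what plain phenyl would give at this nitrogen stays open, leaving the share of the methyl in 3-methylphenyl unknown. So does the effect of a group carrying an amine or a carboxylic acid there.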